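Furan-to-thiophene swap on a halogenated nucleoside core

This account rests on a few compounds, and the source may have more. Where it says the series, first, only, none or still open, it means among the compounds named here.

Measured so far:
compound 1 `OC[C@H]1O[C@@H](n2cc(F)c3c(-c4ccoc4)ncnc32)[C@H](O)[C@@H]1O`, 5 nM
compound 2 `OC[C@H]1O[C@@H](n2cc(F)c3c(-c4ccsc4)ncnc32)[C@H](O)[C@@H]1O`, 66 nM
compound 3 `OC[C@H]1O[C@@H](n2cc(Cl)c3c(-c4ccoc4)ncnc32)[C@H](O)[C@@H]1O`, 54 nM

Three compounds share one nucleoside-like core and were tested in a functional assay on DU-145 cells (Homo sapiens), read by sulforhodamine B assay, with a stated time of 5 days; on this read-out higher numbers stand for weaker inhibition of growth and lower numbers for stronger inhibition of growth. In this assay compound 1 gives 5 nM. Compound 2 differs from compound 1 in one place: thiophen-3-yl in place of furan-3-yl on an aromatic carbon. That change brought a 13-fold higher number from compound 1 to compound 2 (1.12 log units; beyond the scatter). Compound 3 differs from compound 1 at a separate spot on the core: chloro in place of fluoro on an aromatic carbon. That change brought an 11-fold higher number from compound 1 to compound 3 (1.03 log units; beyond the scatter). Compound 2 and compound 3 thus lie close together, and their two values fall within the usual scatter of one another.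

Compound 4 `OC[C@H]1O[C@@H](n2cc(Cl)c3c(-c4ccsc4)ncnc32)[C@H](O)[C@@H]1O` has not been measured. It differs from compound 3 by thiophen-3-yl in place of furan-3-yl on an aromatic carbon. The place is described in exactly the same words as for the change from compound 1 to compound 2, so this is the same change, made on the core that already carries chloro in place of fluoro.

Among the compounds with values here, the one example of this change gave a large weakening in growth inhibition. Starting from the weaker compound 3, compound 4 is expected to move by about a 7.4-fold higher number from compound 3 to compound 4 (0.87 log units; beyond the scatter) in this assay, because the earlier step was a 13-fold higher number from compound 1 to compound 2 (1.12 log units; beyond the scatter). Two weakening changes need not add fully, so the expected step is taken somewhat smaller than the first. Compound 4 is estimated at 400 nM, with a plausible range from 120 nM to 1500 nM.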

Compound 4, concentration for 50% growth inhibition: 18 nM
Beside the measured number, compound 4's estimate is 22-fold (1.35 log units) above it; the measured number lies below the stated range.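

In this assay, thiophen-3-yl in place of furan-3-yl now gave a 3.0-fold lower number from compound 3 to compound 4 (0.48 log units; beyond the scatter), so on the chloro core the change strengthens growth inhibition, whereas on the fluoro core it weakened it: the same change on two cores in this assay, a 13-fold higher number (1.12 log units; beyond the scatter) from compound 1 to compound 2 and a 3.0-fold lower number (0.48 log units; beyond the scatter) from compound 3 to compound 4, 40-fold (1.60 log units) apart, beyond the scatter of two such steps. Chloro in place of fluoro shows the same reversal, with a 3.7-fold lower number from compound 2 to compound 4 (0.56 log units; beyond the scatter) on the thiophen-3-yl compounds, the opposite direction to its step on the furan-3-yl compounds: the same change on two cores in this assay, an 11-fold higher number (1.03 log units; beyond the scatter) from compound 1 to compound 3 and a 3.7-fold lower number (0.56 log units; beyond the scatter) from compound 2 to compound 4, 40-fold (1.60 log units) apart, beyond the scatter of two such steps. These two comparisons come from the same four compounds, and they show that in this set neither change carries a fixed effect from one core to the other, since its size and even its direction depend on the group at the other place, but they do not show why this happens or whether it extends beyond these four compounds.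

Going by these compounds, it remains open whether the same reversal would appear with bromo or methyl in the place of the halogen, or with phenyl or an amine in the place of the five-membered ring. On these data alone, it is also open whether the four compounds would keep this pattern in cells other than those of this assay.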